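The compounds below may be only part of what the source reports. "The series", "measured", "known", "first", "only" and "open" are said of these compounds alone.

In an ADME assay on HEK-293T cells (Homo sapiens) for inhibition, read by CCK-8 assay, with a stated time of 48 h, tested at 20 uM (on this read-out lower numbers stand for less inhibition of growth and higher numbers for more inhibition of growth at the one concentration tested), compound 1 (`N#C/C(=C\c1ccccc1OS(=O)(=O)c1ccc(F)cc1)C(=O)Nc1nnc(Cc2ccccc2)s1`) gives 6% and compound 2 (`COc1ccc(S(=O)(=O)Oc2ccccc2/C=C(\C#N)C(=O)Nc2nnc(Cc3cccc(F)c3)s2)cc1`) gives 29%. Compound 2 is the higher of the two numbers, beyond the scatter. Compound 3 (`N#C/C(=C\c1ccccc1OS(=O)(=O)c1ccc(F)cc1)C(=O)Nc1nnc(Cc2cccc(F)c2)s1`) differs from compound 2 by fluoro in place of methoxy on an aromatic carbon, with fluoro in place of methoxy on an aromatic carbon. Within the data shown here, no measured pair isolates this change. A moderate fall is expected, since compound 1, which also carries (4-fluorophenyl)sulfonyl, stands at 6%. The expected step is a number 12 percentage points lower from compound 2 to compound 3 (beyond the scatter), and it may not clear the scatter. For compound 3 the estimated value is 17%, with an expected range of 4% to 34%.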

Compound 3, percent growth inhibition at one concentration: 17%
For compound 3 middle estimate and measured number coincide at the digits printed; measured number inside the range.
By their numbers in this assay, from the lowest: compound 1; then compound 3; then compound 2.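

In this assay, among these compounds, fluoro in place of methoxy on the sulfonyl-bearing aromatic ring gives a number 12 percentage points lower from compound 2 to compound 3 (beyond the scatter) and provides the first single-place reading at this position. Fluoro in place of hydrogen on an aromatic carbon elsewhere in the compound gives a number 11 percentage points higher from compound 1 to compound 3 (beyond the scatter) and is likewise modest. Compound 3 therefore links compound 1 and compound 2 through two single changes that move the read-out in opposite directions.

On these data alone, whether an amine or a carboxylic acid at this position would read differently remains open, as does whether the methoxy-to-fluoro step holds without the second fluoro group. No available evidence bears on the cause of either step.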